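Isopropyl Side Chain in Place of the Methylsulfanyl Chain

The compounds below may be only part of what the source reports. "The series", "measured", "known", "first", "only" and "open" are said of these compounds alone.

Compound 1 `CC(C)(C)OC(=O)NCCCC[C@H](NC(=O)CN(c1ncnc2c1ncn2C1CCCCO1)C1CC1)C(=O)OCc1ccccc1`: 32.9%
Compound 2 `CSCC[C@H](NC(=O)CN(c1ncnc2c1ncn2C1CCCCO1)C1CC1)C(=O)OCc1ccccc1`: 42.7%

Among the measured compounds shown here, in a functional assay on the whole organism (Tail, strain ICR) with Mus musculus as the target, in the tail flick test, with a stated time of 90 min, at a dose of 25 umol/kg by the oral route (on this read-out higher numbers stand for a stronger effect at the one dose given and lower numbers for a weaker effect), compound 2 gives the higher of the two numbers, yet the only measured step, a number 9.8 percentage points higher from compound 1 to compound 2 (within the scatter), lies within the scatter, so the two compounds cannot be ordered. Compound 3 `CC(C)[C@H](NC(=O)CN(c1ncnc2c1ncn2C1CCCCO1)C1CC1)C(=O)OCc1ccccc1` differs from compound 2 in this way: isopropyl in place of 2-(methylsulfanyl)ethyl on a saturated chain carbon bound to an amide-type nitrogen and a carbonyl carbon. That single step, a number 9.8 percentage points higher from compound 1 to compound 2 (within the scatter), also altered the side chain and produced nothing beyond the scatter, so no step beyond the scatter is expected here either. Compound 3 is therefore estimated at 38%, within 20% to 56%. The estimated step is a number 4.7 percentage points lower from compound 2 to compound 3 (within the scatter).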

Compound 3, a percentage reported as activity, at one dose (the size of the read-out at that dose, not a potency): 30.1%
The estimate for compound 3 lay 7.9 percentage points above the measured number; the measured number falls inside the stated range.
By their numbers in this assay, from the lowest: compounds 3, 1 and 2 (each within the scatter of the next, the first and the last beyond it).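

In this assay, this position gives its first step beyond the scatter: isopropyl in place of 2-(methylsulfanyl)ethyl yields a number 12.6 percentage points lower from compound 2 to compound 3 (beyond the scatter), a modest loss. Isopropyl in place of 4-((tert-butoxycarbonyl)amino)butyl yields a number 2.8 percentage points lower from compound 1 to compound 3 (within the scatter), which lies within the scatter, so these two side chains cannot be told apart here. No evidence is available to explain either step.

Still open, as far as these compounds go, is how a side chain ending in a free amine or a carboxylic acid would read at this carbon, and whether a longer thioether chain would differ from 2-(methylsulfanyl)ethyl.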